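This account rests on a few compounds, and the source may have more. Where it says the series, first, only, none or still open, it means among the compounds named here.

Compound 3 `Cc1ccccc1NC(=O)CN1CCN(c2nnc(Cc3ccncc3)c3ccccc23)CC1` stands at the top of the three numbers measured in a functional assay on MDA-MB-231 cells (Homo sapiens) for cytotoxicity, read by MTT assay, with a stated time of 72 h; on this read-out lower numbers stand for stronger inhibition and higher numbers for weaker inhibition: compound 3 gives 200 nM, while compound 1 `O=C(CN1CCN(c2nnc(Cc3ccncc3)c3ccccc23)CC1)Nc1cccc(F)c1` gives 4.4 nM and compound 2 `O=C(CN1CCN(c2nnc(Cc3ccncc3)c3ccccc23)CC1)Nc1ccc(F)c(C(F)(F)F)c1` gives 1.9 nM. The steps onto the amide-type nitrogen were large, a 45-fold higher number from compound 1 to compound 3 (1.66 log units; beyond the scatter) and a 110-fold higher number from compound 2 to compound 3 (2.02 log units; beyond the scatter), whereas a 2.3-fold lower number from compound 1 to compound 2 (0.36 log units; beyond the scatter) was modest. Compound 4 `Cc1cccc(Cl)c1NC(=O)CN1CCN(c2nnc(Cc3ccncc3)c3ccccc23)CC1` differs from compound 3 by chloro in place of hydrogen on an aromatic carbon. For the measured compounds named here, no measured step adds a single chloro to this ring; the only step that adds halogen-bearing groups, a 2.3-fold lower number from compound 1 to compound 2 (0.36 log units; beyond the scatter), was modest. For compound 4 the expected step is therefore a 1.3-fold lower number from compound 3 to compound 4 (0.12 log units; within the scatter), near or within the scatter. Compound 4 is estimated at 150 nM, with a range of 50 nM to 600 nM.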

Compound 4, half-maximal inhibitory concentration: 2670 nM
Estimate against measurement, compound 4: 18-fold (1.25 log units) below; measured number outside the range, above it.
By their numbers in this assay, from the lowest: compound 2; then compound 1; then compound 3; then compound 4.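

Compound 3 had shown that the 2-methylphenyl group gives a high number, and the new result shows that a single chloro on that ring, ortho to a large group, raises it further, with a 13-fold higher number from compound 3 to compound 4 (1.13 log units; beyond the scatter) in this assay. The 2-chloro-6-methylphenyl group also stands far from the other two aryl groups, with a 610-fold higher number from compound 1 to compound 4 (2.78 log units; beyond the scatter) and a 1400-fold higher number from compound 2 to compound 4 (3.15 log units; beyond the scatter). No evidence is at hand on what lies behind these steps. The compounds shown leave open whether a fluoro or a methoxy group on this carbon would give a similar step. They also leave open what the 2-chlorophenyl group, without the methyl, would give.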